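The source may hold more compounds than are shown below. What is called first, only, known or untested is meant among the compounds shown, and "the series" means these compounds.

Measured in a functional assay on KYSE-410 cells (Homo sapiens) for antiproliferative activity, read by MTT assay, with a stated time of 72 h; on this read-out lower numbers stand for stronger inhibition and higher numbers for weaker inhibition:
Compound 1 `COc1ccc(-c2ccc3c(C(=O)Nc4cccc(F)c4)cc(=O)[nH]c3c2)cc1`: 18000 nM
Compound 2 `O=C(Nc1cccc(F)c1)c1cc(=O)[nH]c2cc(-c3ccncc3)ccc12`: > 20000 nM (a limit of the assay)
Compound 3 `O=C(Nc1cccc(F)c1)c1cc(=O)[nH]c2cc(C3=CCOCC3)ccc12`: 12100 nM

Compound 3 lies within the scatter of compound 1, while compound 2 is known only through its limit. Compound 4 `C=Cc1ccc2c(C(=O)Nc3cccc(F)c3)cc(=O)[nH]c2c1` differs from compound 3 at one aromatic carbon, where vinyl replaces the non-aromatic ring: a group of 2 heavy atoms (2 carbon; no ring) in place of a group of 6 heavy atoms (5 carbon, 1 oxygen; one six-membered non-aromatic ring with 1 hetero atom), on an aromatic carbon is the change. The measured steps at this carbon are a 1.5-fold lower number from compound 1 to compound 3 (0.17 log units; within the scatter) and an at least 1.1-fold higher number from compound 1 to compound 2 (0.04 log units; that floor lies within the scatter) and an at least 1.6-fold lower number from compound 2 to compound 3 (0.21 log units; that floor lies within the scatter) and all three lie within the scatter. No step beyond the scatter is therefore expected in this assay from this change. The estimated step is a 1.2-fold higher number from compound 3 to compound 4 (0.06 log units; within the scatter) in size. For compound 4 the estimate is 14000 nM with an expected range from 6000 nM to 28000 nM overall.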

Compound 4, half-maximal inhibitory concentration: 13600 nM
Estimate against measurement, compound 4: 1.0-fold (0.01 log units) above, within the range that was stated.
By their numbers in this assay, from the lowest: compounds 3, 4 and 1 (each within the scatter of the next). At a limit, above all of these: compound 2.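

In this assay, vinyl, which has no ring, gives a number level with those of the two larger ring groups at this aromatic carbon: a 1.1-fold higher number from compound 3 to compound 4 (0.05 log units; within the scatter), and a 1.3-fold lower number from compound 1 to compound 4 (0.12 log units; within the scatter). A ring at this carbon is therefore not needed for a number in this range, as compound 4 shows. The remaining step, an at least 1.4-fold lower number from compound 2 to compound 4 (0.16 log units; that floor lies within the scatter), gives only a floor and rests on a limit: the limit of > 20000 nM in this assay, at which 1 of the 4 values shown sits.

Still open, going by these compounds, is whether an amine, a carboxylic acid or a longer chain at this carbon would move the number beyond the scatter.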